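The source may report more compounds than this note shows. Statements on the series, on what has been measured and on what is new or still open speak of the compounds shown alone.

Three compounds share one core and differ only in the group on the amide-type nitrogen. Compound 1 has the structure `CNC(=O)c1c(NO)cc(-c2ccccc2)oc1=O`, compound 2 has `CCCNC(=O)c1c(NO)cc(-c2ccccc2)oc1=O`, and compound 3 has `CC(C)NC(=O)c1c(NO)cc(-c2ccccc2)oc1=O`. In an ADME assay on Huh-7 cells (Homo sapiens) for cytotoxicity, read by a luciferase reporter and WST assay, with a stated time of 3 days (a lower number here means that less compound is tolerated, a higher number that more compound is tolerated), compound 3 reaches only a limit of > 20000 nM. Compound 1 likewise gives a limit of > 20000 nM in this assay. Compound 2 also gives a limit of > 20000 nM in this assay. Because all three sit at the limit of > 20000 nM in this assay, at which 3 of the 3 values shown sit, the steps between them cannot be sized: a step that the two limits leave unreadable from compound 1 to compound 2, a step that the two limits leave unreadable from compound 1 to compound 3 and a step that the two limits leave unreadable from compound 2 to compound 3. Compound 4, not yet measured, has the structure `O=C(NCCCO)c1c(NO)cc(-c2ccccc2)oc1=O`, and its difference from compound 3 is 3-hydroxypropyl in place of isopropyl on an amide-type nitrogen. Going by the values given here, none of the measured steps can be read, so they give no direction; what they do show is that every measured compound tolerates the highest amount tested. Compound 4 is therefore expected to sit at that same limit, an expected step that the limit leaves unreadable from compound 3 to compound 4. The estimate for compound 4 in this assay is 30000 nM, ranging from 15000 nM to 80000 nM.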

Compound 4, half-maximal cytotoxic concentration: > 20000 nM
Compound 4 was reported as a limit; the forecaster's own chance of this, stated with the estimate: 85%; the middle value lies beyond the limit too.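

Compound 4 also gives only a limit, so its steps from compound 1, compound 2 and compound 3 cannot be read, and all four compounds share one result: the limit of > 20000 nM in this assay, at which 4 of the 4 values shown sit. The compounds shown leave open whether these groups on the amide-type nitrogen differ at all in this assay.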